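The compounds below may be only part of what the source reports. "The series", "measured", "known", "first", "only" and "open" are said of these compounds alone.

Measured compounds:
compound 1 `O=C(NCCCCN1CCCCC1)Nc1ccc(-c2ccccn2)nc1` — > 30000 nM (limit)
compound 2 `O=C(NCCCCN1CCCCC1)Nc1ccc(-c2ccccc2)nc1` — > 30000 nM (limit)

In a functional assay on HEK293 cells for agonist activity at 5-hydroxytryptamine receptor 3A (Homo sapiens), read by FLIPR (a higher number here means a weaker inhibitor, a lower number a stronger inhibitor), compound 1 reaches only the limit of the assay, > 30000 nM. Compound 2 likewise stops at the limit, > 30000 nM. The step that the two limits leave unreadable from compound 1 to compound 2 is accordingly not readable; both values sit at the limit of > 30000 nM in this assay, at which 2 of the 2 values shown sit, and neither size nor direction of the exchange to phenyl can be taken from it.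

Within the data shown here, compound 2 stands at the limit in this assay, as does the only other value shown, so no order within the pair can be stated.

Compound 3 is `O=C(NCCCCN1CCCCC1)Nc1ccc(-c2ccc(F)nc2)nc1`. The change from compound 2 is 6-fluoropyridin-3-yl in place of phenyl on an aromatic carbon. Among the measured compounds shown here, the single measured step, a step that the two limits leave unreadable from compound 1 to compound 2, concerns the same place on the shared core and is itself unreadable, so it offers no measured size to carry over. Expected in this assay is no readable step: a number no higher from compound 2 to compound 3 (the limit leaves the size open). Compound 3 is therefore expected to sit at the limit as well, at 30000 nM with a range of 10000 nM to 100000 nM.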

Compound 3, half-maximal inhibitory concentration: > 30000 nM
Compound 3 gave a limit, no number (the forecaster's own chance of this, stated with the estimate: 85%); the middle value lies on the limit itself.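

In this assay compound 3 gives > 30000 nM, a limit and not a number. Neither the step to compound 3 from compound 2 nor the one from compound 1 can be read, and all three compounds share one value: the limit of > 30000 nM in this assay, at which 3 of the 3 values shown sit.

The compounds shown leave open whether any group at this place on the shared core gives a measurable number in this assay.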